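The source may report more compounds than this note shows. Statements on the series, on what has been measured and on what is new or still open speak of the compounds shown alone.

The small set shares one core and differs only in two substituents on its ring. Compound 1 is `O=c1cc(I)n([C@@H]2O[C@H](CO)[C@@H](O)[C@H]2O)c(=O)[nH]1`. Compound 2 is `[N-]=[N+]=Nc1cc(=O)[nH]c(=O)n1[C@@H]1O[C@H](CO)[C@@H](O)[C@H]1O`. Compound 3 is `O=c1[nH]c(=O)n([C@@H]2O[C@H](CO)[C@@H](O)[C@H]2O)c(I)c1F`. The as yet unmeasured compound 4 is `[N-]=[N+]=Nc1c(F)c(=O)[nH]c(=O)n1[C@@H]1O[C@H](CO)[C@@H](O)[C@H]1O`.

In a functional assay on OCI-Ly7 cells (Homo sapiens) for antiproliferative activity, read by WST assay, with a stated time of 3 days (a lower number here means a stronger inhibitor, a higher number a weaker inhibitor), compound 1 gives no number but only a limit, > 50000 nM. In this assay compound 2 also gives only a limit, > 50000 nM. Compound 3 reaches only a limit as well in this assay, > 50000 nM.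

The change from compound 1 to compound 2 is azido in place of iodo on an aromatic carbon. The step it made, a step that the two limits leave unreadable from compound 1 to compound 2, cannot be read because of the limit of > 50000 nM in this assay, at which 3 of the 3 values shown sit. The two cores, those of compound 1 and compound 3, differ by fluoro in place of hydrogen on an aromatic carbon; that step, a step that the two limits leave unreadable from compound 1 to compound 3, is equally unreadable, both its values being limits.

The change from compound 3 to compound 4 is azido in place of iodo on an aromatic carbon, the same kind of change as from compound 1 to compound 2; around the place they differ in that the azido of compound 4 sits ortho to a fluoro group (1 heavy atom), which is not so in compound 2. The step from compound 3 to compound 4 is expected to be a number no higher from compound 3 to compound 4 (the limit leaves the size open), resting on the earlier change, whose step that the two limits leave unreadable from compound 1 to compound 2 left both compounds at the limit. Compound 4 is therefore estimated at 50000 nM, with a strong chance that this assay again reports only a limit for it.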

Compound 4, half-maximal inhibitory concentration: 700 nM
Compound 4: the middle estimate sits 71-fold (1.85 log units) above what was measured, outside the stated range (below it).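

In this assay, azido in place of iodo on the fluoro-bearing core gives an at least 71-fold lower number from compound 3 to compound 4 (1.85 log units; beyond the scatter), and fluoro in place of hydrogen on the azido-bearing core gives an at least 71-fold lower number from compound 2 to compound 4 (1.85 log units; beyond the scatter). The azido change therefore does not carry over unchanged from the core of compound 1 to the core of compound 3: it yields a large, measurable step only where the azido sits ortho to a fluoro group, and among the four compounds only compound 4, which holds both groups, gives a number rather than a limit. What this does not show is how large the two new steps really are or how far the azido change differs between the two cores, since the steps from compound 1 to compound 2 and from compound 1 to compound 3 cannot be read and both new steps are bounded on one side only, because each starts from a limit: the limit of > 50000 nM in this assay, at which 3 of the 4 values shown sit.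

The compounds shown leave open whether an amine or a nitrile in place of the azido would give a step of this kind on the fluoro-bearing core, and whether chloro or methyl in place of the fluoro would allow the azido to do the same. They also leave open whether the result for compound 4 extends to any read-out other than this assay.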